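Adding One Methoxy to Compound 2

This account rests on a few compounds, and the source may have more. Where it says the series, first, only, none or still open, it means among the compounds named here.

In a functional assay on MDA-MB-231 cells (Homo sapiens) for antiproliferative activity, read by sulforhodamine B assay, with a stated time of 48 h (on this read-out higher numbers stand for weaker inhibition and lower numbers for stronger inhibition), compound 1 (`COc1cc(C(=O)/C=C\Nc2ccc(-c3nc4cc(OC)c(OC)c(OC)c4s3)cc2C)cc([N+](=O)[O-])c1OC`) gives 12800 nM, and compound 2 (`COc1cc(OC)c2sc(-c3ccc(N/C=C\C(=O)c4ccc(OC)c([N+](=O)[O-])c4)c(C)c3)nc2c1`) gives 10800 nM. Among the compounds with values here, these two values lie within the usual scatter of each other, so compound 2 stands level with the only other measured compound. Compound 3 (`COc1cc(OC)c2sc(-c3ccc(N/C=C\C(=O)c4cc(OC)c(OC)c([N+](=O)[O-])c4)c(C)c3)nc2c1`) comes from compound 2 by one change: methoxy in place of hydrogen on an aromatic carbon, ortho to a methoxy group and meta to a nitro group (methoxy in place of hydrogen on an aromatic carbon). Within the data shown here, no measured step shows what this change does in this assay, so the expected step of a 1.0-fold higher number from compound 2 to compound 3 (0.01 log units; within the scatter) stays within the scatter, with no direction favoured. For compound 3 the estimated value is 11000 nM, with an expected range of 5000 nM to 25000 nM.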

Compound 3, half-maximal inhibitory concentration: 7400 nM
The estimate for compound 3 lay 1.5-fold (0.17 log units) above the measured number, within the range that was stated.
By their numbers in this assay, from the lowest: compounds 3, 2 and 1 (each within the scatter of the next).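

Within the data shown here, the first measured step at this position, a 1.5-fold lower number from compound 2 to compound 3 (0.16 log units; within the scatter) in this assay, lies within the scatter, so methoxy in place of hydrogen here, ortho to a methoxy group and meta to a nitro group, gives no clear gain or loss. The step of a 1.7-fold lower number from compound 1 to compound 3 (0.24 log units; within the scatter) swaps hydrogen for methoxy on an aromatic carbon elsewhere and also stays within the scatter. No supporting measurement bears on either result. Still open, on these data alone, is whether an amine, a hydroxyl or a longer alkoxy chain at this position would shift the number beyond the scatter.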